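Ethyl in Place of Chloro: What to Expect for Compound 4

The source may hold more compounds than are shown below. What is called first, only, known or untested is meant among the compounds shown, and "the series" means these compounds.

Of the compounds shown here, three sharing one core have been measured in a functional assay for inhibition, with Rattus norvegicus as the target; on this read-out lower numbers stand for stronger inhibition and higher numbers for weaker inhibition. Compound 1 `CC(C)(C)/N=c1\c(O)c(O)\c1=N/Cc1ccc(F)cc1F` gives 2100 nM. Compound 2 `CC(C)(C)/N=c1\c(O)c(O)\c1=N/Cc1ccc(C#N)c(Cl)c1` gives 1100 nM, and compound 3 `CCC(C)(C)/N=c1\c(O)c(O)\c1=N/Cc1ccc(F)c(F)c1` gives 1600 nM. Compound 2 has the lowest number of the three, yet its gaps to compound 3 and to compound 1 both fall within the usual scatter, so no ranking can be read from these three values.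

Compound 4 `CCc1cc(C/N=c2\c(O)c(O)\c2=N/C(C)(C)C)ccc1C#N` differs from compound 2 in a single spot: ethyl in place of chloro on an aromatic carbon. Within the data shown here, no measured pair shows this exchange, so its effect is unknown here. A small step is expected, in neither direction beyond the scatter. Compound 4 is expected to give about 1300 nM, within 500 nM to 3500 nM. The expected step in this assay is a 1.2-fold higher number from compound 2 to compound 4 (0.07 log units; within the scatter).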

Compound 4, half-maximal inhibitory concentration: 6100 nM
The estimate for compound 4 lay 4.7-fold (0.67 log units) below the measured number, and the stated range ends below it.
By their numbers in this assay, from the lowest: compounds 2, 3 and 1 (each within the scatter of the next); then compound 4.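

At this position, ortho to a cyano group, the choice of group clearly matters: in this assay, ethyl in place of chloro gives a 5.5-fold higher number from compound 2 to compound 4 (0.74 log units; beyond the scatter) and is the only step shown here. Exchanging one heavy atom for two is therefore enough to take the number beyond the scatter. Nothing available explains this rise. The compounds shown leave open how methyl, methoxy or a longer chain such as propyl would read at this position. They also leave open whether the same exchange gives a similar step when the rest of the molecule differs.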